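Thiomorpholine amide on the methylated pyrrolidine core

A few compounds are considered here, and "the series" means these few. Any claim that something is new, unique, unknown or untested is made for them only; others in the source may bear on it.

Measured so far:
Compound 1, `CCN(CC)C(=O)[C@@H]1CN[C@H](C(=O)N2CCC[C@H]2C#N)C1`: "not determined" (no result reported).
Compound 2, `CCCNC(=O)[C@@H]1CN[C@H](C(=O)N2CCC[C@H]2C#N)C1`: 21%.
Compound 3, `CCN(C)C(=O)[C@H]1C[C@@H](C(=O)N2CCC[C@H]2C#N)N[C@H]1C`: 79%.

Three compounds share a pyrrolidine-carbonyl linked to a cyanopyrrolidine, and were examined in an assay on the whole organism (plasma, strain Sprague-Dawley) for inhibition of Dipeptidyl peptidase 4 (Rattus norvegicus), with a stated time of 10 h, at a dose of 1 mg/kg by the oral route; a higher number here means more inhibition at the dose given (going by the name of the read-out), a lower number less inhibition. Compound 1 carries a diethylamino amide; in this assay compound 1 gives "not determined" (no result reported), so no number is reported for it. Compound 2, with a propylamino amide, gives 21% in this assay. Compound 3 places a methyl on the shared core and an ethyl(methyl)amino amide; in this assay compound 3 gives 79%, the highest of the two numbers reported, and it stands far above compound 2, a gap beyond the usual scatter. Within the data shown here, since compound 2 and compound 3 differ in more than one place, no single step between them is described.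

Compound 4, `C[C@@H]1N[C@H](C(=O)N2CCC[C@H]2C#N)C[C@@H]1C(=O)N1CCSCC1`, keeps the methylated core of compound 3 and changes only the amide: thiomorpholin-4-yl in place of ethyl(methyl)amino on a carbonyl carbon. Both compound 3 and compound 4 carry a tertiary amide on that carbonyl carbon, so the expected step from compound 3 to compound 4 in this assay is small, at most a modest drop, likely not beyond the scatter; that expected step is a number 11 percentage points lower from compound 3 to compound 4 (beyond the scatter). Compound 4 is therefore estimated to give 68% in this assay, with a range from 42% to 86%.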

Compound 4, a percentage reported as inhibition, in the whole organism at one dose (the size of the read-out at that dose, not a potency): 85%
Compound 4: middle estimate off by 17 percentage points, on the low side; measured number inside the range.
By their numbers in this assay, from the lowest: compound 2; then compounds 3 and 4 (each within the scatter of the next).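

Among these compounds, at this place, on a carbonyl carbon whose other neighbours are saturated ring carbon, the earlier compounds offered no single-change comparison; here, thiomorpholin-4-yl in place of ethyl(methyl)amino gives a number 6 percentage points higher from compound 3 to compound 4 (within the scatter) in this assay. The swap brings in a six-membered non-aromatic ring with 2 hetero atoms, one of them sulfur, along with a hydrogen-bond acceptor, yet this read-out at a single dose does not separate the two tertiary amides, so this open-chain amide and this ring amide cannot be told apart here. Nothing measured here speaks to why the two amides read alike.

The compounds shown leave open how much of the read-out belongs to the methyl on the shared core, since no pair here differs in that methyl alone. They also leave open whether the result would carry over to a morpholin-4-yl amide, with oxygen in the place of sulfur, or to a piperidin-1-yl amide, with carbon there, on the same methylated core.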